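Methyl for Iodo on a Shared Anilide Core

The compounds below may be only part of what the source reports. "The series", "measured", "known", "first", "only" and "open" are said of these compounds alone.

Three compounds have been measured in a functional assay on K562 cells (Homo sapiens) for inhibition, read by trypan blue exclusion, with a stated time of 24 h, tested at 10 uM; a higher number here means more inhibition of growth at the concentration tested, a lower number less inhibition of growth:

Compound 1 `NC(=O)c1cc(I)ccc1NC(=O)COc1ccccc1`: 73%
Compound 2 `NC(=O)c1cc(I)ccc1NC(=O)COc1ccc(Cl)cc1Cl`: 74.7%
Compound 3 `Cc1ccc(NC(=O)COc2ccccc2)c(C(N)=O)c1`: 72%

Compound 1 and compound 3 differ in one place, (methyl in place of iodo on an aromatic carbon). That step, a number 1 percentage points lower from compound 1 to compound 3 (within the scatter), left the read-out essentially where it was. Compound 2 stands alongside compound 1 in this assay; how the cores of compound 1 and compound 2 differ is not broken down here, and their two values lie within the scatter of each other, as do those of compound 2 and compound 3.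

Compound 4 `Cc1ccc(NC(=O)COc2ccc(Cl)cc2Cl)c(C(N)=O)c1` has not yet been measured in this assay. It relates to compound 2 as compound 3 relates to compound 1: methyl in place of iodo on an aromatic carbon, the same change at the same place. Because the earlier step of a number 1 percentage points lower from compound 1 to compound 3 (within the scatter) was within the scatter, the step from compound 2 to compound 4 is expected to be similar, a number 1.2 percentage points lower from compound 2 to compound 4 (within the scatter). On that basis compound 4 is estimated to give 73.5% in this assay, expected to fall between 63% and 82%.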

Compound 4, percent growth inhibition at one concentration: 35.4%
Compound 4: the middle estimate sits 38.1 percentage points above what was measured; the whole stated range lies above it.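

In this assay, methyl in place of iodo gave a number 39.3 percentage points lower from compound 2 to compound 4 (beyond the scatter), so this change did not keep its size when carried from one core to the other: the same change on two cores in this assay, a number 1 percentage points lower (within the scatter) from compound 1 to compound 3 and a number 39.3 percentage points lower (beyond the scatter) from compound 2 to compound 4, 38.3 percentage points apart, beyond the scatter of two such steps

The two pairs show that, in this series, a step that is silent on the core of compound 1 cannot be assumed to be silent on the core of compound 2. They do not show which feature of the core sets the size of the step, and two pairs give no rule for any further core.

The compounds shown leave open whether the drop at compound 4 follows the loss of iodo or the arrival of methyl, a question that a bromo, an ethyl or a methoxy group at the same place on the core of compound 2 could help to settle. They also leave open how the two cores would compare across other concentrations, since the read-out here comes from a single one.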